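The compounds below may be only part of what the source reports. "The series", "measured", "known", "first", "only" and "open" are said of these compounds alone.

In a physicochemical assay for solubility, in phosphate buffer, measured as thermodynamic solubility, at pH 7.4 (on this read-out higher numbers stand for higher solubility and lower numbers for lower solubility), compound 1 `CS(=O)(=O)NC(=O)CCc1cn(-c2ccncc2)nc1-c1ccc(Cl)cc1` gives 190000 nM. Compound 2 `CNC(=O)CCc1cn(-c2ccc(Br)cc2)nc1-c1ccc(Cl)cc1` gives < 5000 nM, which is a limit of the assay and not a number. Compound 3 `Clc1ccc(-c2nn(-c3ccc(Br)cc3)cc2CCc2nnn[nH]2)cc1` keeps the rest of compound 2 but has 1H-tetrazol-5-yl in place of methylcarbamoyl on a saturated chain carbon, two bonds along the chain from an aromatic carbon. Among the measured compounds shown here, no measured step between compounds differing in one place covers this change, so any forecast is loose. A rise is still expected, resting on compound 1 at 190000 nM, whose side chain also ends in something other than methylcarbamoyl, although it differs elsewhere too. The expected change, an at least 10-fold higher number from compound 2 to compound 3 (1.00 log units; beyond the scatter), is an estimated rise beyond the scatter in this assay. For compound 3 the estimated solubility is 50000 nM, with an expected range from 8000 nM to 250000 nM.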

Compound 3, solubility: 150000 nM
The estimate for compound 3 lay 3.0-fold (0.48 log units) below the measured number; the range from low to high includes it.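

In this assay, the swap on a saturated chain carbon, two bonds along the chain from an aromatic carbon, can now be read at this one place: 1H-tetrazol-5-yl in place of methylcarbamoyl gives an at least 30-fold higher number from compound 2 to compound 3 (1.47 log units; beyond the scatter). Compound 1 differs from the other two in more than one place, so it could not show that the number moves beyond the scatter with the rest of compound 2 held the same. The true size of the step stays unknown, as compound 2 stands at a limit of the assay and not at a number: the limit of < 5000 nM in this assay, at which 1 of the 3 values shown sits.

This single pair does not tell whether the rise belongs to 1H-tetrazol-5-yl in particular or would also come with a carboxylic acid or an amine at the end of the chain. On these data alone, how a longer chain carrying 1H-tetrazol-5-yl would read also remains open.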